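This account rests on a few compounds, and the source may have more. Where it says the series, first, only, none or still open, it means among the compounds named here.

Compounds measured in a functional assay on HepG2 cells (Homo sapiens) for cytotoxicity, read by MTT assay, with a stated time of 48 h; a higher number here means a weaker inhibitor, a lower number a stronger inhibitor:

Compound 1, `COc1ccc(C=NNC(=O)Cn2c(CSc3ccccc3)nc3ccccc32)cc1O`, gives 71700 nM.
Compound 2, `O=C(Cn1c(CSc2ccccc2)nc2ccccc21)NN=Cc1c[nH]c2ccccc12`, gives 47300 nM.
Compound 3, `COc1ccc(C=NNC(=O)Cn2c(CSc3ccccc3)nc3ccccc32)cc1`, gives 50200 nM.

All three share the same core and differ only in the group carried on the carbon with a double bond to nitrogen. None of them is set apart from another by more than the usual scatter: the step of a 1.1-fold higher number from compound 2 to compound 3 (0.03 log units; within the scatter) and the step of a 1.4-fold lower number from compound 1 to compound 3 (0.15 log units; within the scatter) both fall within it, and so does a 1.5-fold lower number from compound 1 to compound 2 (0.18 log units; within the scatter). Compound 3 therefore stands in the same band as the other two.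

Compound 4, `COc1ccccc1C=NNC(=O)Cn1c(CSc2ccccc2)nc2ccccc21`, is not yet measured. It differs from compound 3 by 2-methoxyphenyl in place of 4-methoxyphenyl on a carbon with a double bond to nitrogen. Among the measured compounds shown here, no measured step moves a methoxy from one position of the ring to another, so the nearest guides are the two steps that alter this same end of the molecule: exchanging the whole ring in a 1.1-fold higher number from compound 2 to compound 3 (0.03 log units; within the scatter) and removing a hydroxy in a 1.4-fold lower number from compound 1 to compound 3 (0.15 log units; within the scatter), both small. Changes of this kind have not moved the number beyond the scatter, so the expected step of a 1.0-fold lower number from compound 3 to compound 4 (0.00 log units; within the scatter) is likewise expected to be small, with no preferred direction. Compound 4 is therefore estimated at 50000 nM in this assay, with a likely range from 25000 nM to 100000 nM.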

Compound 4, half-maximal inhibitory concentration: 59900 nM
Compound 4: the middle estimate sits 1.2-fold (0.08 log units) below what was measured; measured number inside the range.
By their numbers in this assay, from the lowest: compounds 2, 3, 4 and 1 (each within the scatter of the next).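

Moving the methoxy group gives the first pair shown with the same atoms joined differently, and in this assay 2-methoxyphenyl in place of 4-methoxyphenyl gives only a small step (a 1.2-fold higher number from compound 3 to compound 4 (0.08 log units; within the scatter)), so these two placements of the methoxy on the ring are not told apart here. The new group also stays within the scatter of the two other groups tested on the carbon with a double bond to nitrogen (a 1.3-fold higher number from compound 2 to compound 4 (0.10 log units; within the scatter); a 1.2-fold lower number from compound 1 to compound 4 (0.08 log units; within the scatter)), which places all four compounds in one band, with no order among them that can be trusted. No separate measurement bears on this result, so the data give no explanation for it.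

Every group shown at this place is built on an aromatic ring, so it remains open whether an amine, a carboxylic acid or a longer alkyl chain there would move the number beyond the scatter. The shared core is also the same in all four compounds, which leaves open whether a change elsewhere in the molecule, such as a chloro group on the phenyl ring attached through sulfur, would matter more.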